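Methylating the phenol of a 4-methoxyphenyl isoquinoline series

A few compounds are considered here, and "the series" means these few. Any claim that something is new, unique, unknown or untested is made for them only; others in the source may bear on it.

Measured so far:
compound 1 `COc1ccc(-c2cc3ccccc3c(-c3cccc(N)c3)n2)cc1`, 2350 nM
compound 2 `COc1ccc(-c2cc3ccccc3c(-c3ccc(O)cc3)n2)cc1`, > 50000 nM

In a functional assay on HCT-15 cells (Homo sapiens) for cytotoxicity, read by CCK-8 assay and cell counting, with a stated time of 72 h (on this read-out lower numbers stand for stronger inhibition and higher numbers for weaker inhibition), compound 2 gives only a limit, > 50000 nM; this value is a limit of the assay (the limit of > 50000 nM in this assay, at which 1 of the 2 values shown sits), not a number. Compound 3 `COc1ccc(-c2cc3ccccc3c(-c3ccc(OC)cc3)n2)cc1` differs from compound 2 by methyl in place of hydrogen on an oxygen on an aromatic ring. Within the data shown here, no measured step covers this change; the only step available is an at least 21-fold higher number from compound 1 to compound 2 (1.32 log units; beyond the scatter), which concerns a different substituent. With compound 2 at the limit, compound 3 is expected to remain weak in this assay, with the step of an at least 1.6-fold lower number from compound 2 to compound 3 (0.22 log units; that floor lies within the scatter) uncertain in direction. The estimate for compound 3 is 30000 nM, within 5000 nM to 100000 nM.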

Compound 3, half-maximal inhibitory concentration: 2790 nM
Compound 3: the middle estimate sits 11-fold (1.03 log units) above what was measured; measured number outside the range, below it.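

In this assay, methyl in place of hydrogen on the oxygen of the 4-hydroxyphenyl group moves the read-out from a limit to a measured value (an at least 17-fold lower number from compound 2 to compound 3 (1.25 log units; beyond the scatter)). Compound 2 stands at a limit, not a number: the limit of > 50000 nM in this assay, at which 1 of the 3 values shown sits. On the shared core, 4-methoxyphenyl and 3-aminophenyl cannot be told apart (a 1.2-fold higher number from compound 1 to compound 3 (0.07 log units; within the scatter)).

On these data alone, the full size of the hydroxy to methoxy step stays open, as only its floor is known. As far as these compounds go, how an ethoxy or a longer chain on that oxygen, or an amine or a carboxylic acid in place of the methoxy, would read also remains open.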